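The source may report more compounds than this note shows. Statements on the series, on what has been measured and on what is new or still open speak of the compounds shown alone.

Compound 1 `CC(C)c1ccc2c(Nc3cc(C(=O)N[C@@](C)(CO)c4ccccc4)ccc3Sc3ccc(N)cc3)ncnc2n1` gives 900 ng.h/mL in an ADME assay on the whole organism (plasma, strain Sprague-Dawley) for pharmacokinetics, with Rattus norvegicus as the target, at a dose of 5 mg/kg by the oral route; on this read-out lower numbers stand for lower exposure and higher numbers for higher exposure at the dose given.
Compound 2 `CC(C)c1ccc2c(Nc3cc(C(=O)N[C@@H](C)c4ccc(Br)cc4)ccc3Sc3ccc(N)cc3)ncnc2n1` gives 3840 ng.h/mL in this assay.

Compound 2 holds the higher of the two numbers in this assay; its nearest neighbour is compound 1, and the step of a 4.3-fold higher number from compound 1 to compound 2 (0.63 log units; beyond the scatter) separates them, a change on the amide-type nitrogen of 1-(4-bromophenyl)ethyl in place of 1-(hydroxymethyl)-1-phenylethyl. Compound 3 `CC(C)c1ccc2c(Nc3cc(C(=O)N[C@@H](C)C4CCCCC4)ccc3Sc3ccc(N)cc3)ncnc2n1` has not yet been measured in this assay. It differs from compound 2 as follows: cyclohexyl in place of 4-bromophenyl on a saturated chain carbon bound to an amide-type nitrogen and a saturated chain carbon. No measured step of the two shown replaces a 4-bromophenyl by a cyclohexyl; the only step that touches the same amide-type substituent is the step from compound 1 to compound 2, which moved the number modestly. With nothing closer to draw on, compound 3 is expected to remain near compound 2, with a step of a 1.5-fold lower number from compound 2 to compound 3 (0.19 log units; within the scatter) that may well stay within the scatter. The estimate for compound 3 in this assay is 2500 ng.h/mL, expected to fall between 900 ng.h/mL and 7000 ng.h/mL.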

Compound 3, area under the concentration-time curve: 250 ng.h/mL
Beside the measured number, compound 3's estimate is 10-fold (1.00 log units) above it; the whole stated range lies above it.
By their numbers in this assay, from the lowest: compound 3; then compound 1; then compound 2.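

Exposure in this assay proves highly sensitive to the ring on this saturated chain carbon: cyclohexyl in place of 4-bromophenyl gives a 15-fold lower number from compound 2 to compound 3 (1.19 log units; beyond the scatter) and is a far larger change than the earlier pair suggested. Measured against the 1-(hydroxymethyl)-1-phenylethyl group, 1-cyclohexylethyl on the amide-type nitrogen gives a 3.6-fold lower number from compound 1 to compound 3 (0.56 log units; beyond the scatter) in the opposite direction from 1-(4-bromophenyl)ethyl, so replacing that group does not by itself raise the number. Nothing available explains why the number falls with cyclohexyl.

On these data alone, this step changes the bromine and the aromatic ring together, so the share of each remains open, and a plain phenyl on the same carbon would separate them. As far as these compounds go, it is also open whether a 4-bromocyclohexyl or a 4-chlorophenyl would stay near either measured level.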